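The source may hold more compounds than are shown below. What is called first, only, known or untested is meant among the compounds shown, and "the series" means these compounds.

Compound 1 `C#CCNC(=O)C[C@H](NC(=O)c1ccc(C#Cc2ccccc2)cc1)C(=O)NO` stands beside compound 2 `O=C(NC1(C(=O)NO)CCCCC1)c1ccc(C#Cc2ccccc2)cc1` and compound 3 `O=C(NC1(C(=O)NO)CCOCC1)c1ccc(C#Cc2ccccc2)cc1`, all on the shared core. In a physicochemical assay for solubility (on this read-out lower numbers stand for lower solubility and higher numbers for higher solubility), compound 1 gives 8000 nM, the higher of the two numbers recorded. Compound 3 gives 5000 nM in this assay, a reading within the scatter of compound 1, so no order between the two is claimed. Compound 2 reaches only a limit of the assay, < 1000 nM, not a number; (the limit of < 1000 nM in this assay, at which 1 of the 3 values shown sits). Compound 4 `O=C(C[C@H](NC(=O)c1ccc(C#Cc2ccccc2)cc1)C(=O)NO)NCCCO` remains to be measured. Relative to compound 1 it differs in one place: 2-hydroxyethyl in place of ethynyl on a saturated chain carbon bound to an amide-type nitrogen. For the measured compounds named here, no measured pair isolates this change. A modest upward step in this assay is expected, a 1.8-fold higher number from compound 1 to compound 4 (0.24 log units; within the scatter), not clearly beyond the scatter. Compound 4 is estimated at 14000 nM, within 6000 nM to 35000 nM.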

Compound 4, solubility: 82000 nM
Beside the measured number, compound 4's estimate is 5.9-fold (0.77 log units) below it; measured number above the stated range.
By their numbers in this assay, from the lowest: compounds 3 and 1 (each within the scatter of the next); then compound 4. At a limit, below all of these: compound 2.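

In this assay, 2-hydroxyethyl in place of ethynyl on a saturated chain carbon bound to an amide-type nitrogen gives a 10-fold higher number from compound 1 to compound 4 (1.01 log units; beyond the scatter), a large step. This place on the side chain therefore moves the read-out, which compounds 1, 2 and 3 could not show, as none of them forms a one-place pair. Nothing on hand gives a cause for this step.

From the compounds shown here alone, whether the step follows the loss of the triple bond or the gain of the hydroxyl stays open. A plain propyl chain, a longer hydroxyalkyl chain, an amine or a carboxylic acid at this place would separate these readings.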